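The source may report more compounds than this note shows. Statements on the series, on what has been measured and on what is new or still open speak of the compounds shown alone.

Measured compounds in an ADME assay on Vero cells (Chlorocebus sabaeus) for cytotoxicity, read by MTT assay, with a stated time of 48 h; on this read-out lower numbers stand for stronger inhibition and higher numbers for weaker inhibition:
compound 1 `O=C(OC1CCC(CN2CCN(c3cc(=O)c4cc(C(F)(F)F)cc([N+](=O)[O-])c4s3)CC2)CC1)c1ccc(F)cc1` gives > 64 ug/mL, a limit of this assay.
compound 2 `Cc1ccc(C(=O)OC2CCC(CN3CCN(c4cc(=O)c5cc(C(F)(F)F)cc([N+](=O)[O-])c5s4)CC3)CC2)cc1` gives > 64 ug/mL, a limit of this assay.
compound 3 `O=C(OC1CCC(CN2CCN(c3cc(=O)c4cc(C(F)(F)F)cc([N+](=O)[O-])c4s3)CC2)CC1)c1ccccc1` gives > 64 ug/mL, a limit of this assay.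

Compound 3 stands only at a limit on this read-out, and the two further values shown are limits as well (the limit of > 64 ug/mL in this assay, at which 3 of the 3 values shown sit). The steps a step that the two limits leave unreadable from compound 1 to compound 3 and a step that the two limits leave unreadable from compound 2 to compound 3 are therefore not readable in size, and the same holds for a step that the two limits leave unreadable from compound 1 to compound 2.

Compound 4 `O=c1cc(N2CCN(CC3CCC(NS(=O)(=O)c4ccccc4)CC3)CC2)sc2c([N+](=O)[O-])cc(C(F)(F)F)cc12` differs from compound 3 by (phenylsulfonyl)amino in place of benzoyloxy on a saturated ring carbon. Among the measured compounds shown here, no measured step touches this position; the measured steps all concern the substituent on the aromatic ring of the ester. For compound 4 the expected step is a step that the limit leaves unreadable from compound 3 to compound 4, with no direction beyond the scatter to be drawn from the measured steps. Compound 4 is therefore estimated at 80 ug/mL in this assay, expected between 40 ug/mL and 200 ug/mL, most likely again reported only as a limit.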

Compound 4, half-maximal inhibitory concentration: > 64 ug/mL
Compound 4: no number, only a limit; the forecaster's own chance of this, stated with the estimate: 85%; the middle value does not contradict the limit.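

Compound 4 joins compound 1, compound 2 and compound 3 at a limit, so no step among them can be read: the limit of > 64 ug/mL in this assay, at which 4 of the 4 values shown sit.

The compounds shown leave open both the size and the direction of any change from the aromatic substituent of the ester or from (phenylsulfonyl)amino in place of benzoyloxy.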